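From 2-ethylphenyl to 2,4-dimethylphenyl: compound 3 to compound 4

A few compounds are considered here, and "the series" means these few. Any claim that something is new, unique, unknown or untested is made for them only; others in the source may bear on it.

Values measured in an ADME assay on Huh7.5.1 cells (Homo sapiens) for cytotoxicity, read by ATP content, with a stated time of 48 h; a lower number here means that less compound is tolerated, a higher number that more compound is tolerated:
- compound 1 `Cc1cc(C)c(-c2nc(CN3CCC(C(=O)NCCCN4C[C@H](C)C[C@H](C)C4)CC3)c(C)o2)c(C)c1`: 6570 nM
- compound 2 `Cc1oc(-c2c(Cl)cccc2C(F)(F)F)nc1CN1CCC(C(=O)NCCCN2C[C@H](C)C[C@H](C)C2)CC1`: 12000 nM
- compound 3 `CCc1ccccc1-c1nc(CN2CCC(C(=O)NCCCN3C[C@H](C)C[C@H](C)C3)CC2)c(C)o1`: 9320 nM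

With 9320 nM, compound 3 lies within the usual scatter of both other compounds, so these three numbers cannot be meaningfully ranked in this assay.

The next molecule, compound 4 `Cc1ccc(-c2nc(CN3CCC(C(=O)NCCCN4C[C@H](C)C[C@H](C)C4)CC3)c(C)o2)c(C)c1`, has the same atoms as compound 3, joined differently, with 2,4-dimethylphenyl in place of 2-ethylphenyl on an aromatic carbon.

Three measured steps change the group at this same place: a 1.4-fold higher number from compound 1 to compound 3 (0.15 log units; within the scatter), a 1.3-fold lower number from compound 2 to compound 3 (0.11 log units; within the scatter) and a 1.8-fold higher number from compound 1 to compound 2 (0.26 log units; within the scatter). None of these three exchanges moved the number beyond the scatter. Among the measured groups, the name 2,4,6-trimethylphenyl in compound 1 comes closest to the entering group, and compound 1 gives 6570 nM. That suggests a slight lean towards its number, though no step beyond the scatter is expected.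

The expected step is a 1.2-fold lower number from compound 3 to compound 4 (0.08 log units; within the scatter). For compound 4 the estimated value is 7800 nM, with an expected range from 4500 nM to 13500 nM.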

Compound 4, half-maximal cytotoxic concentration: 4110 nM
The estimate for compound 4 lay 1.9-fold (0.28 log units) above the measured number, outside the stated range (below it).
By their numbers in this assay, from the lowest: compounds 4, 1, 3 and 2 (each within the scatter of the next, the first and the last beyond it).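

In this assay, for the compounds shown here, this position shows steps beyond the scatter for the first time: there is a 2.3-fold lower number from compound 3 to compound 4 (0.36 log units; beyond the scatter) and a 2.9-fold lower number from compound 2 to compound 4 (0.47 log units; beyond the scatter), both modest in size. The first of these keeps the same atoms and only rearranges them, from 2-ethylphenyl to 2,4-dimethylphenyl, so the number here can move without any change in the count of heavy atoms, whereas replacing one methyl of the 2,4,6-trimethylphenyl group with hydrogen gives a 1.6-fold lower number from compound 1 to compound 4 (0.20 log units; within the scatter), which stays within the scatter. No measurement shown here accounts for either shift.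

The compounds shown leave open whether the lower number of compound 4 belongs to the 2,4-dimethylphenyl arrangement in particular, since a plain phenyl, a 2-methylphenyl or a 4-methylphenyl group at this place would be needed to separate the contribution of each methyl. They also leave open whether a 4-ethylphenyl group, which would move the ethyl chain of compound 3 to a different ring carbon, would stay near compound 3 or fall towards compound 4.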